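Dropping the Nitro Group: From Compound 2 to Compound 3

The compounds below may be only part of what the source reports. "The series", "measured", "known", "first", "only" and "open" are said of these compounds alone.

compound 1 `O=[N+]([O-])c1ccc(-c2nnc(SCCCN3CCN(c4nc5ccccc5o4)CC3)o2)cc1`: 90800 nM
compound 2 `O=[N+]([O-])c1ccc(-c2nnc(SCCCN3CCN(c4nc5ccccc5s4)CC3)o2)cc1`: 96600 nM

In a functional assay on A549 cells (Homo sapiens) for inhibition, read by MTT assay, with a stated time of 72 h (on this read-out higher numbers stand for weaker inhibition and lower numbers for stronger inhibition), compound 1 gives 90800 nM and compound 2 gives 96600 nM. Compound 2 holds the higher of the two numbers, with compound 1 nearest, but the step of a 1.1-fold higher number from compound 1 to compound 2 (0.03 log units; within the scatter) lies within the scatter, so no order between the two can be drawn. Compound 3 `c1ccc(-c2nnc(SCCCN3CCN(c4nc5ccccc5s4)CC3)o2)cc1` has not yet been measured. It differs from compound 2 by hydrogen in place of nitro on an aromatic carbon. Within the data shown here, the only measured step, a 1.1-fold higher number from compound 1 to compound 2 (0.03 log units; within the scatter), concerns the ring on the amine nitrogen and not the nitro group, so no measured step bears directly on this change. Resting only on compound 2 at 96600 nM, the step of a 1.1-fold higher number from compound 2 to compound 3 (0.06 log units; within the scatter) is expected, that is, essentially nothing beyond the scatter. Compound 3 is therefore estimated at 110000 nM, with a range from 45000 nM to 270000 nM.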

Compound 3, half-maximal inhibitory concentration: 257000 nM
Compound 3: middle estimate off by 2.3-fold (0.37 log units), on the low side; the measured number falls inside the stated range.
By their numbers in this assay, from the lowest: compounds 1 and 2 (each within the scatter of the next); then compound 3.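

In this assay, the aromatic carbon bearing the nitro group proves to be the first place in this series where a single change moves the number beyond the scatter: going from 4-nitrophenyl to phenyl gives a modest loss of inhibition (a 2.7-fold higher number from compound 2 to compound 3 (0.42 log units; beyond the scatter)), whereas the exchange on the amine nitrogen gave no readable difference (a 1.1-fold higher number from compound 1 to compound 2 (0.03 log units; within the scatter)). Of this pair, the 4-nitrophenyl compound therefore has the stronger inhibition, although all three numbers are of a similar high order on this read-out. No measurement accompanying these compounds accounts for the step.

From the compounds shown here alone, whether the step is particular to nitro remains open, since an amine, a nitrile or a carboxylic acid on the same carbon could give a different number. Also open, going by these compounds, is whether the same step would appear with 1,3-benzoxazol-2-yl on the amine nitrogen.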